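Swapping an amide for an aryl ether on the shared core

A few compounds are considered here, and "the series" means these few. Any claim that something is new, unique, unknown or untested is made for them only; others in the source may bear on it.

Of the compounds shown here, two sharing one core have been measured in an assay for inhibition of inositol hexakisphosphate kinase 3 (Homo sapiens), read by colorimetric assay, coupled enzyme assay and malachite green, with a stated time of 120 min, in the presence of a further agent that is not named here; a lower number here means a stronger inhibitor, a higher number a weaker inhibitor. Compound 1 `O=C(O)c1ccc2noc(-c3ccc(NC(=O)C4CCCC4)cc3)c2c1` carries a (cyclopentylcarbonyl)amino group and in this assay compound 1 gives 240 nM. Compound 2 `O=C(O)c1ccc2noc(-c3cccc(NC(=O)C4CC4)c3)c2c1` carries a (cyclopropylcarbonyl)amino group on a different position of the same ring, and in this assay compound 2 gives 2810 nM, the higher of the two numbers; the two compounds differ in more than one place, so the gap between them is not traced to a single change.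

Compound 3 `O=C(O)c1ccc2noc(-c3cccc(Oc4ccccn4)c3)c2c1` is the next member. It differs from compound 2 in one respect: (pyridin-2-yl)oxy in place of (cyclopropylcarbonyl)amino on an aromatic carbon, at a site meta to a large group. Among the compounds with values here, no measured pair shows how such a swap shifts the number, so the direction is open. Compound 3 is expected to land near compound 2, with the step from compound 2 to compound 3 estimated at a 1.2-fold higher number from compound 2 to compound 3 (0.10 log units; within the scatter), a modest change in either direction. Compound 3 is therefore estimated at 3500 nM, in a range from 900 nM to 14000 nM.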

Compound 3, half-maximal inhibitory concentration: 10900 nM
For compound 3 the middle estimate is 3.1-fold (0.49 log units) below the measured one; the range from low to high includes it.
By their numbers in this assay, from the lowest: compound 1; then compound 2; then compound 3.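

Within the data shown here, the first single-place comparison falls on an aromatic carbon meta to a large group: in this assay, (pyridin-2-yl)oxy in place of (cyclopropylcarbonyl)amino gives a 3.9-fold higher number from compound 2 to compound 3 (0.59 log units; beyond the scatter), a move toward weaker inhibition. At this site, then, the two groups are not interchangeable, although the change does not abolish inhibition, as compound 3 still gives a measurable 10900 nM. The swap replaces a three-membered carbon ring with a six-membered aromatic ring and also removes the hydrogen-bond donor counted in the leaving group, yet nothing shown explains why the number rises.

Because the linking atoms and the terminal ring change together, the compounds shown leave open which of the two accounts for the step, and a (pyridin-2-yl)amino group or a phenoxy group at the same site would separate these two changes. They also leave open whether (pyridin-2-yl)oxy would have the same effect at the ring position that carries the (cyclopentylcarbonyl)amino group in compound 1.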